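The source may hold more compounds than are shown below. What is called first, only, known or untested is meant among the compounds shown, and "the series" means these compounds.

Measured compounds:
- compound 1 `O=C(O)c1cc(-c2cccc(COc3ccc4c(=O)n(C5CCCC5)oc4c3)c2)ccc1Cl`: 64%
- compound 2 `O=C(O)c1cc(-c2cccc(COc3ccc4c(c3)CN(CC3CC3)C4=O)c2)ccc1Cl`: 85.7%
- compound 3 `CC(C)N1Cc2cc(OCc3cccc(-c4ccc(Cl)c(C(=O)O)c4)c3)ccc2C1=O`: 88.1%

In an assay on HEK293 cells for positive allosteric modulation of metabotropic glutamate receptor 2 (Rattus norvegicus), read by thallium flux (a higher number here means a larger maximal response, a lower number a smaller maximal response), compound 3 holds the highest of the three numbers, though compound 2 lies within the scatter of it and only compound 1 sits beyond the scatter below. Compound 4 `CC(C)CCN1Cc2cc(OCc3cccc(-c4ccc(Cl)c(C(=O)O)c4)c3)ccc2C1=O` differs from compound 3 by isopentyl in place of isopropyl on an amide-type nitrogen in a ring. Within the data shown here, the one measured step that bears on this change is a number 2.4 percentage points higher from compound 2 to compound 3 (within the scatter), which also swaps the group on that amide-type nitrogen in a ring and stays within the scatter. Among the measured compounds shown here, since only that single step is known, and it trades a different pair of groups, the expectation rests on little. Compound 4 is therefore expected to give 86%, within a range from 72% to 98%, which amounts to an expected step of a number 2.1 percentage points lower from compound 3 to compound 4 (within the scatter), not beyond the scatter.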

Compound 4, largest response reached (Emax), in percent of the reference or control that the assay uses: 85.3%
Estimate against measurement, compound 4: 0.7 percentage points above; low and high end bracket the measured number.
By their numbers in this assay, from the lowest: compound 1; then compounds 4, 2 and 3 (each within the scatter of the next).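

In this assay, a chain of five carbons on the amide-type nitrogen gives a number 2.8 percentage points lower from compound 3 to compound 4 (within the scatter) and, with isobutyl in place of cyclopropyl on the carbon bound to that nitrogen, a number 0.4 percentage points lower from compound 2 to compound 4 (within the scatter). Isopropyl, cyclopropylmethyl and isopentyl on this nitrogen therefore all lie within the scatter of one another, so the added carbons leave the maximal response unmoved in this small set. No measured evidence here explains this result. Still open, as far as these compounds go, is whether an amine or a carboxylic acid on that chain, or a phenyl ring there, would keep this response.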